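The compounds below may be only part of what the source reports. "The series", "measured", "known", "first", "only" and "open" are said of these compounds alone.

In an ADME assay on the whole organism (Macaca fascicularis) for pharmacokinetics, read by LC-MS, using cassette dosing; a lower number here means that a smaller share of the oral dose reaches the circulation, a higher number that a larger share of the oral dose reaches the circulation: compound 1 `CCCCN(c1nc2ccccc2o1)[C@H](C)c1ccc(-c2ccccc2-c2nnn[nH]2)cc1` gives 1.8%; compound 2 `CCCCN(c1nc2c(C(=O)O)cccc2o1)[C@H](C)c1ccc(-c2cc(Cl)ccc2-c2nc(=O)o[nH]2)cc1` gives 42%.

Compound 1 stands lowest of the two numbers; compound 2 lies higher by a gap beyond the scatter, but compound 2 differs from compound 1 in several places, so the pair shows only its two values. Compound 3 `CCCCN(c1nc2c(C(=O)N(C)C)cccc2o1)[C@H](C)c1ccc(-c2ccccc2-c2nnn[nH]2)cc1` carries dimethylcarbamoyl in place of hydrogen on an aromatic carbon. Among the measured compounds shown here, no single-change step for this is known; the expected step is a number 8.2 percentage points higher from compound 1 to compound 3 (within the scatter), upward, perhaps just beyond the scatter, since compound 1 starts so low at 1.8%. Compound 3 is estimated at 10%, with a range from 2% to 30%.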

Compound 3, oral bioavailability: 6.7%
Beside the measured number, compound 3's estimate is 3.3 percentage points above it; the measured number falls inside the stated range.
By their numbers in this assay, from the lowest: compounds 1 and 3 (each within the scatter of the next); then compound 2.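

In this assay, among the compounds shown here, the first single-place step at this aromatic carbon, dimethylcarbamoyl in place of hydrogen, gives a number 4.9 percentage points higher from compound 1 to compound 3 (within the scatter) on the core of compound 1. Taken alone, this group at this position therefore produces no step beyond the scatter in oral bioavailability. No measured evidence bears on the reason for this result. Compound 2 differs from compound 1 in several places, so the part played by its carboxylic acid at this carbon cannot be read. Also open, as far as these compounds go, is whether an amine or a hydroxymethyl group here, on the same core, would give a step beyond the scatter.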